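A few compounds are considered here, and "the series" means these few. Any claim that something is new, unique, unknown or untested is made for them only; others in the source may bear on it.

Compound 3 `C=CCc1cc(C(C)=O)c(O)cc1OCCCCCCC` stands lowest of the three measured compounds in an assay on isolated protein for inhibition of leukotriene B4 receptor 1 (Homo sapiens), tested at 10 uM; on this read-out higher numbers stand for more inhibition at the one concentration tested (going by the name of the read-out) and lower numbers for less inhibition: compound 3 gives 31%, while compound 2 `C=CCc1cc(C(C)=O)c(O)cc1OCCCCCC` gives 50% and compound 1 `C=CCc1cc(C(C)=O)c(O)cc1OCCCCCCC#N` gives 97%. Compound 4 `C=CCc1cc(C(C)=O)c(O)cc1OCCCCCC(C)=O` differs from compound 3 by acetyl in place of ethyl on a saturated chain carbon, five bonds along the chain from an oxygen on an aromatic ring. Among the measured compounds shown here, three measured steps bear on this change, all pointing the same way: a number 47 percentage points lower from compound 1 to compound 2 (beyond the scatter), a number 66 percentage points lower from compound 1 to compound 3 (beyond the scatter) and a number 19 percentage points lower from compound 2 to compound 3 (beyond the scatter). A large rise in this assay is therefore expected for compound 4, because compound 1 gives 97% with a nitrile on the chain where compounds 2 and 3 carry only hydrogen or methyl. Compound 4 is estimated at 75%, within a range from 45% to 95%. The expected step is a number 44 percentage points higher from compound 3 to compound 4 (beyond the scatter).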

Compound 4, a percentage reported as inhibition, at one concentration (the size of the read-out at that concentration, not a potency): 98%
Compound 4: middle estimate off by 23 percentage points, on the low side; measured number above the stated range.
By their numbers in this assay, from the lowest: compound 3; then compound 2; then compounds 1 and 4 (each within the scatter of the next).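

Acetyl on the saturated chain carbon, five bonds along the chain from an oxygen on an aromatic ring, replaces ethyl with a number 67 percentage points higher from compound 3 to compound 4 (beyond the scatter) and methyl with a number 48 percentage points higher from compound 2 to compound 4 (beyond the scatter). The nitrile of compound 1 is thus not the only chain ending that gives such a number: acetyl in place of cyanomethyl gives a number 1 percentage points higher from compound 1 to compound 4 (within the scatter). No measurement here explains why these two groups match. Going by these compounds, whether an amide or a carboxylic acid in this place would do the same stays open, as does the effect of a longer chain carrying the acetyl.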